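Methyl to methoxy on the hydrazone aryl ring

This account rests on a few compounds, and the source may have more. Where it says the series, first, only, none or still open, it means among the compounds named here.

Three compounds have been measured in an ADME assay on HT-29 cells (Homo sapiens) for inhibition, read by MTT assay, with a stated time of 72 h; a lower number here means a stronger inhibitor, a higher number a weaker inhibitor:

compound 1, `CN(C)C/C=C/C(=O)Nc1cccc(Nc2nc(N/N=C/c3c[nH]c4ccccc34)ncc2Cl)c1`, gives 9680 nM
compound 2, `C/C(=N\Nc1ncc(Cl)c(Nc2cccc(NC(=O)/C=C/CN(C)C)c2)n1)c1ccc(F)cc1F`, gives 3460 nM
compound 3, `C/C(=N\Nc1ncc(Cl)c(Nc2cccc(NC(=O)/C=C/CN(C)C)c2)n1)c1ccc(C)cc1`, gives 11800 nM

Compound 3 has the highest number of the three, but its gap to compound 1 is within the scatter; only compound 2 is separated from it, by a 3.4-fold higher number from compound 2 to compound 3 (0.53 log units; beyond the scatter). Compound 4, `COc1ccc(/C(C)=N/Nc2ncc(Cl)c(Nc3cccc(NC(=O)/C=C/CN(C)C)c3)n2)cc1`, is not yet measured; it differs from compound 3 by methoxy in place of methyl on an aromatic carbon, on an aromatic carbon of a six-membered aromatic ring of carbon only, para to a large group.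

The step that bears most closely on this change is the one at the same ring, a 3.4-fold higher number from compound 2 to compound 3 (0.53 log units; beyond the scatter), a modest step. The other measured step, a 1.2-fold higher number from compound 1 to compound 3 (0.09 log units; within the scatter), replaces the whole group on the hydrazone nitrogen and lies within the scatter. Going by the values given here, no measured pair exchanges methyl for methoxy, so nothing in these data points to a large step in either direction. Compound 4 is therefore expected to sit close to compound 3, with an estimated step of a 1.2-fold lower number from compound 3 to compound 4 (0.09 log units; within the scatter), within the scatter. The estimate for compound 4 in this assay is 9500 nM, with a range from 3000 nM to 30000 nM.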

Compound 4, half-maximal inhibitory concentration: 6830 nM
Beside the measured number, compound 4's estimate is 1.4-fold (0.14 log units) above it; measured number inside the range.
By their numbers in this assay, from the lowest: compounds 2, 4, 1 and 3 (each within the scatter of the next, the first and the last beyond it).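

In this assay, going by these compounds alone, the first direct exchange at this aromatic carbon, methoxy in place of methyl, gives a 1.7-fold lower number from compound 3 to compound 4 (0.24 log units; within the scatter), so this change does not move the number beyond the scatter. With 4-methoxyphenyl on the same carbon, the comparison with 2,4-difluorophenyl gives a 2.0-fold higher number from compound 2 to compound 4 (0.30 log units; within the scatter), and exchanging the whole group on the hydrazone nitrogen gives a 1.4-fold lower number from compound 1 to compound 4 (0.15 log units; within the scatter), which places compound 4 within the scatter of each of the other three, although compound 2 and compound 3 remain separated. No measurement here offers an explanation for these steps.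

The compounds shown leave open whether a longer chain such as ethoxy, or an amine or a carboxylic acid, on this aromatic carbon would give a step beyond the scatter. They also do not separate the contributions of the two fluorines in 2,4-difluorophenyl, which 4-fluorophenyl could address.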